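Swapping an Ether for a Sulfide on a Diamine Core

The source may report more compounds than this note shows. Statements on the series, on what has been measured and on what is new or still open speak of the compounds shown alone.

Compound 1, `Nc1cc(N)c2nc(-c3ccccc3)c(Oc3ccc(Cl)c(Cl)c3)nc2c1`, was tested in a functional assay on CCRF-CEM cells (Homo sapiens) for inhibition, read by sulforhodamine B assay, with a stated time of 48 h; on this read-out higher numbers stand for lower toxicity in this test and lower numbers for higher toxicity in this test. In this assay compound 1 gives < 100000 nM, which is a limit of the assay rather than a number. A second compound, compound 2, `COc1ccc(CNc2nc3cc(N)cc(N)c3nc2-c2ccccc2)cc1`, carries a different group on the shared core; in this assay compound 2 gives < 100000 nM, again only a limit. Where compound 1 stands is therefore easy to state: the limit of < 100000 nM in this assay, at which 2 of the 2 values shown sit, so neither compound is separated from the other, and no step between measured compounds can be drawn.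

Compound 3, `COc1ccc(Sc2nc3cc(N)cc(N)c3nc2-c2ccccc2)cc1`, differs from compound 1 in one place: (4-methoxyphenyl)sulfanyl in place of 3,4-dichlorophenoxy on an aromatic carbon. The change sits on an aromatic carbon of a six-membered aromatic ring that holds two nitrogen atoms, part of a fused or bridged system of two rings, next to the ring nitrogen.

With both measured values sitting at the limit, the step from compound 1 to compound 3 is expected to be a step that the limit leaves unreadable from compound 1 to compound 3, with no basis for a change beyond the scatter in either direction. Compound 3 is therefore expected to give 60000 nM, within 15000 nM to 200000 nM, and most likely once more only a limit.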

Compound 3, concentration lethal to 50% of the cells: < 100000 nM
Compound 3: a limit, no number (the forecaster's own chance of this, stated with the estimate: 80%); the middle value lies beyond the limit too.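

The step from compound 1 to compound 3 cannot be read, because both results are limits of the assay rather than numbers: the limit of < 100000 nM in this assay, at which 3 of the 3 values shown sit.

The compounds shown leave open whether (4-methoxyphenyl)sulfanyl in place of 3,4-dichlorophenoxy changes anything in this assay, and how compound 1, compound 2 and compound 3 would rank there.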